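The source may hold more compounds than are shown below. What is called first, only, known or untested is meant among the compounds shown, and "the series" means these compounds.

Working notes on the series, read in a functional assay on A549 cells (Homo sapiens) for inhibition, read by sulforhodamine B assay, with a stated time of 72 h; on this read-out lower numbers stand for stronger inhibition and higher numbers for weaker inhibition. Among the measured compounds shown here, compound 1 (`Nc1sc(-c2ccc(Cl)cc2)c(-c2ccc(Cl)cc2)c1C(=O)NC1CCCCC1`) gives 2410 nM, while compound 2 (`Nc1sc(-c2ccc(Cl)cc2)c(-c2ccc(Cl)cc2)c1C(=O)Nc1ccccc1`) gives 25000 nM, the higher of the two numbers measured so far. The next structure is compound 3 (`Nc1sc(-c2ccc(Cl)cc2)c(-c2ccc(Cl)cc2)c1C(=O)NC1CCC(O)CC1`), which replaces the phenyl of compound 2 with 4-hydroxycyclohexyl on an amide-type nitrogen: 4-hydroxycyclohexyl in place of phenyl on an amide-type nitrogen.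

For the measured compounds named here, one measured step bears on this change: a 10-fold higher number from compound 1 to compound 2 (1.02 log units; beyond the scatter), a large step that came with phenyl in place of cyclohexyl on an amide-type nitrogen. Leaving phenyl in the opposite direction is therefore expected to give a large step towards a lower number. Going by the values given here, no measured compound carries 4-hydroxycyclohexyl, and the series offers no direct measure of what that group does compared with cyclohexyl. The expected step is therefore set somewhat smaller than the measured one, with a wide range, and compound 1 at 2410 nM serves as the nearest reference. The estimated step is a 6.3-fold lower number from compound 2 to compound 3 (0.80 log units; beyond the scatter). For compound 3 the expected value is 4000 nM, with an estimated range of 1300 nM to 13000 nM.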

Compound 3, half-maximal inhibitory concentration: 250 nM
Compound 3: the middle estimate sits 16-fold (1.20 log units) above what was measured; the measured number lies below the stated range.
By their numbers in this assay, from the lowest: compound 3; then compound 1; then compound 2.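

In this assay, adding a hydroxy to a saturated ring carbon of the cyclohexyl brings a gain of its own, a 9.6-fold lower number from compound 1 to compound 3 (0.98 log units; beyond the scatter), so the group on the amide-type nitrogen is sensitive not only to the choice between an aromatic and a saturated ring but also to substitution on the saturated ring. The full change of phenyl to 4-hydroxycyclohexyl spans a 100-fold lower number from compound 2 to compound 3 (2.00 log units; beyond the scatter), which is wider than the earlier 10-fold higher number from compound 1 to compound 2 (1.02 log units; beyond the scatter) and makes compound 3 the strongest inhibitor of the three, with its steps to both others beyond the scatter. No measurement shown here accounts for the effect of the hydroxy on this read-out.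

Going by these compounds, it remains open whether the gain belongs to the hydroxy itself or would also come with an amine, a methoxy group or a carboxylic acid on the same ring carbon. Also open, on these data alone, is whether a hydroxy would give a similar gain on the phenyl of compound 2, as 4-hydroxyphenyl, or on an open chain such as 2-hydroxyethyl on the amide-type nitrogen.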